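The source may report more compounds than this note shows. Statements on the series, on what has been measured and on what is new or still open speak of the compounds shown alone.

The measured compounds:

Compound 1, `CCN(Cc1cccs1)C(=O)COc1ccc(C)cc1`, in an assay on HEK293 cells for agonist activity at transient receptor potential cation channel subfamily M member 8 (Homo sapiens), read by fluorescence and calcium flux, with a stated time of 15 min (on this read-out lower numbers stand for an effect already at smaller amounts and higher numbers for an effect only at larger amounts of compound), gives 8 nM.
Compound 2, `CCCN(Cc1cccs1)C(=O)COc1ccc(C)cc1`, gives in this assay 40 nM.

Within the data shown here, compound 2 carries the higher of these two numbers; the only step that connects them reads a 5.0-fold higher number from compound 1 to compound 2 (0.70 log units; beyond the scatter), where a methyl was added on the saturated chain carbon two bonds along the chain from the amide-type nitrogen. Compound 3, `Cc1ccc(OCC(=O)N(CCO)Cc2cccs2)cc1`, differs from compound 2 at that same carbon: hydroxy in place of methyl on a saturated chain carbon, two bonds along the chain from an amide-type nitrogen. Among the measured compounds shown here, the one measured step shows that this position is sensitive to change, but neither measured compound carries a hydroxy there, so no step tells which way a hydroxy pulls. Compound 3 is therefore expected to land near compound 2, with a step of a 1.3-fold lower number from compound 2 to compound 3 (0.12 log units; within the scatter), and a wide range. The estimate for compound 3 is 30 nM, between 7 nM and 130 nM.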

Compound 3, half-maximal effective concentration: 900 nM
Beside the measured number, compound 3's estimate is 30-fold (1.48 log units) below it; the measured number lies above the stated range.
By their numbers in this assay, from the lowest: compound 1; then compound 2; then compound 3.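

In this assay, this carbon proves sensitive to more than the addition of an atom: exchanging methyl for hydroxy, one heavy atom for another, gives a larger step (a 23-fold higher number from compound 2 to compound 3 (1.35 log units; beyond the scatter)) than adding the methyl did (a 5.0-fold higher number from compound 1 to compound 2 (0.70 log units; beyond the scatter)). Measured against the hydrogen of the shorter chain, the hydroxy gives a larger step still (a 110-fold higher number from compound 1 to compound 3 (2.05 log units; beyond the scatter)), so the group at this carbon can shift the number substantially. Nothing available here explains why the hydroxy has this effect.

The compounds shown leave open whether this rise belongs to the hydroxy alone or would also appear with another group at this carbon, such as an amine or a methoxy. They also do not show how a longer chain, such as butyl, would compare with propyl.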